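The source may report more compounds than this note shows. Statements on the series, on what has been measured and on what is new or still open speak of the compounds shown alone.

Three amides share one core and differ at the acyl group or the chain amide. Compound 1 `CCCCCCCCNC(=O)[C@@H](NC(=O)c1cccs1)[C@@H](C)O` gives 136000 nM in a functional assay on SW-620 cells (Homo sapiens) for cytotoxicity, read by MTT assay, with a stated time of 48 h; a higher number here means a weaker inhibitor, a lower number a stronger inhibitor. Compound 2 `CCCCCCCCNC(=O)[C@@H](NC(=O)c1nccc2ccccc12)[C@@H](C)O` gives 67800 nM in this assay, the lowest of the three numbers; compound 1 stands nearest, within the scatter, while compound 3 `C/C=C/C=C/C(=O)N[C@H](C(=O)NCCCCCCCC)[C@@H](C)O`, with 200000 nM, lies furthest, beyond the scatter. Among the measured compounds shown here, the single recorded step between measured compounds, a 1.5-fold higher number from compound 1 to compound 3 (0.17 log units; within the scatter), concerns the acyl side only.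

Compound 4 `CCCCCCCCCCCCNC(=O)[C@@H](NC(=O)c1nccc2ccccc12)[C@@H](C)O` differs from compound 2 by butyl in place of hydrogen on a saturated chain carbon, eight bonds along the chain from an amide-type nitrogen. For the measured compounds named here, no measured step touches the chain side, so nothing recorded bears directly on this change. The expectation is therefore a step of a 1.0-fold higher number from compound 2 to compound 4 (0.00 log units; within the scatter), none beyond the scatter. Compound 4 is expected to give about 68000 nM in this assay, within a range from 25000 nM to 180000 nM.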

Compound 4, half-maximal inhibitory concentration: 65800 nM
For compound 4 the middle estimate is 1.0-fold (0.01 log units) above the measured one, and the stated range covers the measured number.
By their numbers in this assay, from the lowest: compounds 4, 2, 1 and 3 (each within the scatter of the next, the first and the last beyond it).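

The chain side now has its first measured step: in this assay, butyl in place of hydrogen on a saturated chain carbon, eight bonds along the chain from an amide-type nitrogen, gives a 1.0-fold lower number from compound 2 to compound 4 (0.01 log units; within the scatter). With this acyl group, the added butyl does not separate compound 4 from compound 2, as the step lies within the scatter. No measurement at hand accounts for this result.

From the compounds shown here alone, whether the butyl change reads the same on the acyl groups of compound 1 and compound 3 remains open. So does whether a longer chain, or an amine or carboxylic acid in place of butyl, would give a step beyond the scatter.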